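Cytotoxicity of Hydantoin Analogues: Phenyl to Isopropyl

The compounds below may be only part of what the source reports. "The series", "measured", "known", "first", "only" and "open" are said of these compounds alone.

Measured compounds:
compound 1 `CCC(C)C(NC(=O)n1nnc2ccccc21)C(=O)NC(c1ccccc1)c1ccccc1`, 40 ug/mL
compound 2 `O=C1NC(c2ccccc2)C(=O)N1C1CCCC1`, 27.4 ug/mL
compound 3 `CC(C)C1NC(=O)N(C2CCCCC2)C1=O`, > 50 ug/mL

In a functional assay on HEL cells (Homo sapiens) for cytotoxicity (a higher number here means that more compound is tolerated, a lower number that less compound is tolerated), compound 2 gives 27.4 ug/mL, the lowest of the two numbers shown; compound 1 gives 40 ug/mL, which lies within the scatter of that value. For compound 3 the result is a limit, (the limit of > 50 ug/mL in this assay, at which 1 of the 3 values shown sits), not a number. Compound 4 `CC(C)C1NC(=O)N(C2CCCC2)C1=O` differs from compound 2 in one place: isopropyl in place of phenyl on a saturated ring carbon. Among the measured compounds shown here, no measured step of this kind is available, so the direction is taken from the limit of compound 3. Compound 4 is expected to be tolerated somewhat better than compound 2, an estimated step of a 1.6-fold higher number from compound 2 to compound 4 (0.22 log units; within the scatter), with a fair chance that only a limit is reported. Compound 4 is estimated at 45 ug/mL, between 25 ug/mL and 80 ug/mL.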

Compound 4, half-maximal cytotoxic concentration: > 50 ug/mL
Compound 4 ended at the assay's limit; the forecaster's own chance of this, stated with the estimate: 45%; at least 1.1-fold (0.04 log units) between middle value and limit.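

In this assay, isopropyl in place of phenyl on this saturated ring carbon gives an at least 1.8-fold higher number from compound 2 to compound 4 (0.26 log units; that floor lies within the scatter), the first step available at this position. On these data alone, this figure is only a floor, so the full size of the change remains unknown. Compound 4 gives > 50 ug/mL, which is a limit and not a number, and that limit is now shared: the limit of > 50 ug/mL in this assay, at which 2 of the 4 values shown sit.

The compounds shown leave open how much compound 4 is actually tolerated. They also leave open whether a methyl, a benzyl or an amine on this ring carbon would behave like isopropyl or like phenyl.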